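The source may report more compounds than this note shows. Statements on the series, on what has been measured and on what is new or still open speak of the compounds shown alone.

Compounds measured in a functional assay on HEK293 cells for agonist activity at Glucose-dependent insulinotropic receptor (Homo sapiens), read by cAMP accumulation, with a stated time of 30 min; a lower number here means that less compound is needed, a higher number that more compound is needed for the effect: compound 1 `COc1c(Nc2ccc(S(C)(=O)=O)cc2F)ncnc1OC1C[C@@H]2COC[C@@H](C1)N2C(=O)OC1(C)CC1` gives 97 nM; compound 2 `CC1(OC(=O)N2CC3COCC(C2)C3Oc2ncnc(Oc3ccccc3F)c2F)CC1` gives 26 nM; compound 3 `CC1(OC(=O)N2CC3COCC(C2)C3Oc2ncnc(Nc3ccc(F)cc3F)c2F)CC1` gives 15 nM.

Compound 3 gives the lowest of the three numbers, but compound 2 lies within the scatter of it, and only compound 1 stands clearly apart. Compound 4 `CC1(OC(=O)N2CC3COCC(C2)C3Oc2ncnc(Nc3ccc(-n4cncn4)cc3F)c2F)CC1` differs from compound 3 by 1H-1,2,4-triazol-1-yl in place of fluoro on an aromatic carbon. Going by the values given here, the one measured step, a 1.7-fold lower number from compound 2 to compound 3 (0.24 log units; within the scatter), concerns a different exchange and does not bear on this change; compound 1, which differs from compound 3 in more than one place, gives only its own value. Nothing in the data therefore predicts the size of this step, and a modest shift is expected, a 2.0-fold higher number from compound 3 to compound 4 (0.30 log units; within the scatter). Compound 4 is estimated at 30 nM, within 8 nM to 120 nM.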

Compound 4, half-maximal effective concentration: 19 nM
For compound 4 the middle estimate is 1.6-fold (0.20 log units) above the measured one; the measured number falls inside the stated range.
By their numbers in this assay, from the lowest: compounds 3, 4 and 2 (each within the scatter of the next); then compound 1.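

In this assay, 1H-1,2,4-triazol-1-yl in place of fluoro gives a 1.3-fold higher number from compound 3 to compound 4 (0.10 log units; within the scatter) and so no difference that stands clear of the scatter. The aromatic carbon meta to a fluoro group thus carries a five-membered aromatic ring with hydrogen-bond acceptors as well as it carries a single fluorine. Nothing measured here accounts for this. From the compounds shown here alone, how an amine, a carboxylic acid or a longer chain would fare on this carbon stays open, as does whether the triazole gives the same result on the core of compound 1.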